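The source may report more compounds than this note shows. Statements on the series, on what has been measured and on what is new or still open speak of the compounds shown alone.

Compound 1 `O=C(N/N=C/c1ccc(F)cc1)Nc1cc2c(Nc3ccc(F)c(Cl)c3)ncnc2cc1O[C@H]1CCOC1` belongs to a small series of three measured compounds that share one core. In a functional assay on PC-3 cells (Homo sapiens) for cytotoxicity, read by MTT assay, with a stated time of 72 h (on this read-out lower numbers stand for stronger inhibition and higher numbers for weaker inhibition), compound 1 is recorded as "not active" (no number reported), so it has no number to serve as a starting point. Its two relatives do have numbers, and both are weak: compound 2 `O=C(N/N=C/c1cccc(Br)c1)Nc1cc2c(Nc3ccc(F)c(Cl)c3)ncnc2cc1O[C@H]1CCOC1` gives 15500 nM, and compound 3 `COc1ccc(/C=N/NC(=O)Nc2cc3c(Nc4ccc(F)c(Cl)c4)ncnc3cc2O[C@H]2CCOC2)cc1` gives 34100 nM.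

The next compound is compound 4 `COc1cc2ncnc(Nc3ccc(F)c(Cl)c3)c2cc1NC(=O)N/N=C/c1ccc(F)cc1`, which differs from compound 1 as follows: methyl in place of oxolan-3-yl on an oxygen on an aromatic ring. In other words, methyl takes the place of oxolan-3-yl on an oxygen on an aromatic ring, and the rest of compound 1 is kept.

Going by the values given here, the only measured step is a 2.2-fold higher number from compound 2 to compound 3 (0.34 log units; beyond the scatter). It is modest, and it concerns the group on a carbon with a double bond to nitrogen, not the group that changes here. Among the compounds with values here, no measured pair tests the exchange of oxolan-3-yl for methyl, so neither the size nor the direction of this step can be read from the data. Within the data shown here, with no number for compound 1, no step can be calculated either. Among the measured compounds shown here, the expectation is therefore only that the new compound stays in the same weak range, and another result without a number remains quite possible. For compound 4, the expected value in this assay is about 25000 nM, with an estimated range from 8000 nM to 70000 nM.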

Compound 4, half-maximal inhibitory concentration: 36500 nM
The estimate for compound 4 lay 1.5-fold (0.16 log units) below the measured number; measured number inside the range.
By their numbers in this assay, from the lowest: compound 2; then compounds 3 and 4 (each within the scatter of the next).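

Compound 4 gives 36500 nM, while compound 1 has no number to set against it, and no new step can be read between compound 1 and compound 4. The compounds shown leave open what the exchange of oxolan-3-yl for methyl does to the value in this assay. Nothing available bears on this result.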